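The source may hold more compounds than are shown below. What is called first, only, known or untested is meant among the compounds shown, and "the series" means these compounds.

Measured values in a functional assay on Jurkat cells (Homo sapiens); a lower number here means a stronger inhibitor, a higher number a weaker inhibitor:

Compound 1 `CC(=O)Nc1cccc(OCC(=O)[C@H](CC(=O)O)NC(=O)[C@@H](NC(=O)COc2cccc3ccccc23)C(C)C)c1` gives > 100000 nM in this assay, which is a limit of the assay and not a number.
Compound 2 `CC(C)[C@H](NC(=O)COc1cccc2ccccc12)C(=O)N[C@@H](CC(=O)O)C(=O)COc1cc(F)ccc1F` gives > 100000 nM in this assay, likewise a limit.
Compound 3 `CC(C)[C@H](NC(=O)COc1cccc2ccccc12)C(=O)N[C@@H](CC(=O)O)C(=O)COc1ccc(F)c(F)c1` gives > 100000 nM in this assay, again a limit.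

Compound 3 therefore stands at the limit of this assay, together with every other measured compound in the series; the three values are not distinguishable (the limit of > 100000 nM in this assay, at which 3 of the 3 values shown sit).

The step to compound 4 `CC(C)[C@H](NC(=O)COc1cccc2ccccc12)C(=O)N[C@@H](CC(=O)O)C(=O)COc1c(Cl)cccc1Cl` is 2,6-dichlorophenyl in place of 3,4-difluorophenyl on an oxygen on a saturated carbon. The measured steps that bear on it are the other exchanges of the aryl on the oxygen on the saturated carbon: a step that the two limits leave unreadable from compound 1 to compound 2, a step that the two limits leave unreadable from compound 1 to compound 3 and a step that the two limits leave unreadable from compound 2 to compound 3. None of them gives a readable size or direction, so no shift beyond the scatter can be expected from them in this assay.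

The expected step is a number no higher from compound 3 to compound 4 (the limit leaves the size open). The estimate for compound 4 in this assay is 100000 nM, within 20000 nM to 500000 nM, with a high chance that only a limit is reported.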

Compound 4, half-maximal inhibitory concentration: 3000 nM
Compound 4: the middle estimate sits 33-fold (1.52 log units) above what was measured; measured number below the stated range.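

In this assay, the aryl on the oxygen on a saturated carbon now proves able to shift the read-out: 2,6-dichlorophenyl in place of 3,4-difluorophenyl gives an at least 33-fold lower number from compound 3 to compound 4 (1.52 log units; beyond the scatter). The same group gives an at least 33-fold lower number from compound 2 to compound 4 (1.52 log units; beyond the scatter) and an at least 33-fold lower number from compound 1 to compound 4 (1.52 log units; beyond the scatter), whereas the exchanges among compound 1, compound 2 and compound 3 cannot be read. Compound 4 is the only one of the four with a number, and the other three remain at a limit of the assay: the limit of > 100000 nM in this assay, at which 3 of the 4 values shown sit.

Compound 4 differs from compound 3 in both the halogen and its ring positions, so the data do not show which of the two carries the step. Also open, from the compounds shown here alone, is how a 2,6-difluorophenyl or a 3,4-dichlorophenyl on the same oxygen would read, either of which would separate the two.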